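A methyl added to compound 2

The source may hold more compounds than are shown below. What is called first, only, known or untested is meant among the compounds shown, and "the series" means these compounds.

In a functional assay on the whole organism for antagonist activity, with Mus musculus as the target (a lower number here means that less compound is needed, a higher number that more compound is needed for the effect), two compounds have been measured:
- compound 1 `Cc1cncn1CC#CC(C)N1CCCC1=O` gives 25.4 mg/kg as its value
- compound 2 `CC1CCC(=O)N1CC#CCn1ccnc1` gives 20.9 mg/kg as its value

Compound 2 stands within the usual scatter of compound 1, so these two values cannot be told apart. Compound 3 `Cc1cncn1CC#CCN1C(=O)CCC1C` is compound 2 with methyl in place of hydrogen on an aromatic carbon. For the measured compounds named here, no measured pair isolates this change, so any guide is indirect. The expected 1.1-fold higher number from compound 2 to compound 3 (0.02 log units; within the scatter) is small, with no shift in either direction beyond the scatter of this assay anticipated. For compound 3 the estimate is 22 mg/kg with an expected range from 9 mg/kg to 55 mg/kg in this measurement.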

Compound 3, dose for half-maximal effect: 14.2 mg/kg
Compound 3: the middle estimate sits 1.5-fold (0.19 log units) above what was measured, and the stated range covers the measured number.
By their numbers in this assay, from the lowest: compounds 3, 2 and 1 (each within the scatter of the next).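

In this assay, methyl in place of hydrogen on an aromatic carbon, next to the ring nitrogen and next to the ring atom that bears a large group, gives a 1.5-fold lower number from compound 2 to compound 3 (0.17 log units; within the scatter). This pair shows that the position can carry a methyl while the value of compound 3 stays within the scatter of compound 2. Nothing available accounts for this result any further.

On these data alone, whether a larger group here, such as an ethyl, a trifluoromethyl or an amine, would also stay within the scatter remains open.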